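Shortening a Side Chain and Adding a Hydroxyl Group

The source may report more compounds than this note shows. Statements on the series, on what has been measured and on what is new or still open speak of the compounds shown alone.

Compound 1 `CCCc1cc(C(C)=O)c(O)cc1OCCCCC#N` and compound 2 `CCCCc1cc(C(C)=O)c(O)cc1OCCCCC#N` share a core and differ only where compound 2 carries a butyl chain in place of propyl. In an assay on isolated protein for inhibition of leukotriene B4 receptor 1 (Homo sapiens), tested at 10 uM (on this read-out higher numbers stand for more inhibition at the one concentration tested (going by the name of the read-out) and lower numbers for less inhibition), compound 1 gives 84%, while compound 2 gives 41%, the lowest of the two numbers measured. Within the data shown here, that difference is the single step measured so far: a number 43 percentage points lower from compound 1 to compound 2 (beyond the scatter).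

Compound 3 `CC(=O)c1cc(CC(C)O)c(OCCCCC#N)cc1O` has not yet been measured. It differs from compound 2 by 1-hydroxyethyl in place of propyl on a saturated chain carbon bound to an aromatic carbon. The propyl that leaves carries no donor or acceptor; the 1-hydroxyethyl that enters brings one hydrogen-bond donor and one acceptor at the saturated chain carbon bound to an aromatic carbon. Among the measured compounds shown here, the one measured step concerns lengthening the chain, not replacing it with a hydroxyl-bearing group, so it bears on this change only loosely: it shows that the read-out is sensitive to what sits at this position. Compound 3 is therefore expected to show a number 4 percentage points higher from compound 2 to compound 3 (within the scatter), an uncertain step. The estimate for compound 3 is 45%, within a wide range from 15% to 75%.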

Compound 3, a percentage reported as inhibition, at one concentration (the size of the read-out at that concentration, not a potency): 10%
For compound 3 the middle estimate is 35 percentage points above the measured one, outside the stated range (below it).
By their numbers in this assay, from the lowest: compound 3; then compound 2; then compound 1.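

The new result shows that this chain position is sensitive to more than length: hydroxy in place of hydrogen on a saturated chain carbon bound to two saturated chain carbons gives a number 74 percentage points lower from compound 1 to compound 3 (beyond the scatter) and takes the read-out to the lowest number of the three. Compared with the butyl chain, which had already lowered the number, 2-hydroxypropyl gives a number 31 percentage points lower from compound 2 to compound 3 (beyond the scatter) even though the two groups have the same count of heavy atoms beyond the ring. So both changes made to the propyl chain of compound 1 lower the number, and the hydroxy change does so with the chain no longer than in compound 2. No measurement here accounts for this drop.

As far as these compounds go, whether a methoxy group or an amine on the same chain carbon would give a similar number remains open. So does the effect of a shorter ethyl chain.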